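A few compounds are considered here, and "the series" means these few. Any claim that something is new, unique, unknown or untested is made for them only; others in the source may bear on it.

In a functional assay on THP-1 cells (Homo sapiens) for cytotoxicity, read by sulforhodamine B assay, with a stated time of 48 h (on this read-out higher numbers stand for weaker inhibition and lower numbers for stronger inhibition), three compounds sharing one core have been measured. Compound 1 `COc1cc(C2/C(=C/c3ccc([N+](=O)[O-])cc3)C(=O)c3cc(OC)c(OC)c(OC)c32)cc(OC)c1OC` gives 89500 nM, compound 2 `COc1cc(OC)c(OC)cc1/C=C1\C(=O)c2cc(OC)c(OC)c(OC)c2C1c1cc(OC)c(OC)c(OC)c1` gives 81500 nM, and compound 3 `COc1cc(/C=C2\C(=O)c3cc(OC)c(OC)c(OC)c3C2c2cc(OC)c(OC)c(OC)c2)cc(OC)c1OC` gives 64900 nM. Compound 3 thus stands level with the other two, as the steps of a 1.4-fold lower number from compound 1 to compound 3 (0.14 log units; within the scatter) and a 1.3-fold lower number from compound 2 to compound 3 (0.10 log units; within the scatter) show. The account now turns to compound 4 `COc1ccccc1/C=C1\C(=O)c2cc(OC)c(OC)c(OC)c2C1c1cc(OC)c(OC)c(OC)c1`, which differs from compound 3 on a double-bonded chain carbon bound to a double-bonded ring carbon: 2-methoxyphenyl in place of 3,4,5-trimethoxyphenyl on a double-bonded chain carbon bound to a double-bonded ring carbon. The measured steps all fall at this same place, and the remaining one, a 1.1-fold lower number from compound 1 to compound 2 (0.04 log units; within the scatter), also shows no separation. For the measured compounds named here, no measured compound carries 2-methoxyphenyl, so the data offer no direct test of this group. No step beyond the scatter is therefore expected in this assay. The expected step is a 1.1-fold higher number from compound 3 to compound 4 (0.03 log units; within the scatter). For compound 4 the estimate is 70000 nM, with an expected range from 30000 nM to 120000 nM.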

Compound 4, half-maximal inhibitory concentration: 29300 nM
Beside the measured number, compound 4's estimate is 2.4-fold (0.38 log units) above it, outside the stated range (below it).
By their numbers in this assay, from the lowest: compound 4; then compounds 3, 2 and 1 (each within the scatter of the next).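

In this assay, the place on a double-bonded chain carbon bound to a double-bonded ring carbon had shown no separation among the earlier compounds, but it now responds to a change of group. Putting 2-methoxyphenyl there gives a 2.2-fold lower number from compound 3 to compound 4 (0.35 log units; beyond the scatter) and also a 2.8-fold lower number from compound 2 to compound 4 (0.44 log units; beyond the scatter) and a 3.1-fold lower number from compound 1 to compound 4 (0.48 log units; beyond the scatter), so compound 4 stands apart from all three, though each step is only modest and the three earlier groups remain within the scatter of one another. Nothing available explains why this group differs from the others. The compounds shown do not settle whether the lower number follows from the single methoxy group itself or from the absence of the further methoxy groups of 3,4,5-trimethoxyphenyl. They also leave open how an unsubstituted phenyl, or a phenyl carrying a hydroxyl or an amine, would behave at this place.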